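Replacing dicyclopropylmethyl with cyclopropyl(phenyl)methyl on the aminopyrimidine nitrogen

The compounds below may be only part of what the source reports. "The series", "measured", "known", "first", "only" and "open" are said of these compounds alone.

Among the compounds with values here, compound 2 `CCCN(c1nccc(-c2c(OC)cc(OC)cc2OC)n1)C(C1CC1)C1CC1` gives 15 nM in an assay on CHO cells for displacement of a labelled ligand from corticotropin-releasing factor receptor 1 (Homo sapiens) (on this read-out lower numbers stand for stronger inhibition and higher numbers for weaker inhibition), the lowest of the two numbers so far; its nearest neighbour is compound 1 `C=CCN(c1nccc(-c2c(OC)cc(OC)cc2OC)n1)C(C1CC1)C1CC1`, which in this assay gives 100 nM, with a 6.7-fold lower number from compound 1 to compound 2 (0.82 log units; beyond the scatter). Compound 3 `CCCN(c1nccc(-c2c(OC)cc(OC)cc2OC)n1)[C@@H](c1ccccc1)C1CC1` differs from compound 2 by cyclopropyl(phenyl)methyl in place of dicyclopropylmethyl on a nitrogen on an aromatic ring. Within the data shown here, no measured step touches this group; the only step known concerns the chain on the same nitrogen and does not bear on it. Without a relevant precedent, no step beyond the scatter is expected, so compound 3 is estimated at 15 nM, range 4 nM to 60 nM, meaning no change at the digits printed from compound 2 to compound 3 (within the scatter).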

Compound 3, inhibition constant: 240 nM
For compound 3 the middle estimate is 16-fold (1.20 log units) below the measured one; the whole stated range lies below it.
By their numbers in this assay, from the lowest: compound 2; then compound 1; then compound 3.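

In this assay the substituent on the nitrogen on an aromatic ring proves sensitive to change: cyclopropyl(phenyl)methyl in place of dicyclopropylmethyl gives a 16-fold higher number from compound 2 to compound 3 (1.20 log units; beyond the scatter). The swap exchanges one three-membered ring for a six-membered aromatic ring and adds a defined stereocentre, so the two changes arrive together and the step cannot be assigned to either. No supporting data explain this step. Open, on these data alone, is how the opposite configuration at that stereocentre would read, and whether a cyclobutyl or an isopropyl group in place of the phenyl ring would keep the number of compound 2.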